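A few compounds are considered here, and "the series" means these few. Any claim that something is new, unique, unknown or untested is made for them only; others in the source may bear on it.

Working notes on the series in a functional assay on HeLa cells (Homo sapiens) for inhibition, read by CCK-8 assay, with a stated time of 48 h; a higher number here means a weaker inhibitor, a lower number a stronger inhibitor. Of the compounds shown here, three have been measured, and none gives a number. Compound 1 `COc1ccc(Oc2ccccc2-c2ccsc2S(=O)(=O)N2CCN(C(=S)Nc3ccc([N+](=O)[O-])cc3)CC2)cc1OC` gives > 50000 nM, which is a limit. Compound 3 `O=C(NCCNS(=O)(=O)c1cc(-c2ccccc2Oc2ccc(O)c(O)c2)cs1)Nc1cc(Cl)cc(Cl)c1` gives > 50000 nM, also a limit. Compound 2 `Nc1ccc(Oc2ccccc2-c2ccc(S(=O)(=O)NCCNC(=O)Nc3ccc(Cl)cc3)s2)cc1` gives > 20000 nM, again a limit. Among the compounds with values here, compound 2 therefore has no rank within this set, and no measured pair offers a step to compare.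

The next compound is compound 4 `O=C(NCCNS(=O)(=O)c1ccc(-c2ccccc2Oc2ccc([N+](=O)[O-])c([N+](=O)[O-])c2)s1)Nc1ccc(Cl)cc1`. It carries 3,4-dinitrophenyl in place of 4-aminophenyl on an oxygen on an aromatic ring, the change from compound 2: 3,4-dinitrophenyl in place of 4-aminophenyl on an oxygen on an aromatic ring.

In this assay no change beyond the scatter is expected, and no direction can be argued from the data. The estimated size is a step that the limit leaves unreadable from compound 2 to compound 4. This expectation rests on compound 2, whose > 20000 nM is a limit. A further limit in place of a number would be no surprise. For compound 4 the expected value is 25000 nM, within an estimated range of 7000 nM to 60000 nM.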

Compound 4, half-maximal inhibitory concentration: > 20000 nM
Compound 4 was reported as a limit; the forecaster's own chance of this, stated with the estimate: 60%; the middle value does not contradict the limit.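

In this assay compound 4 gives > 20000 nM, which is a limit. Compound 2 is also reported as a limit, so no step can be read between compound 2 and compound 4. The compounds shown leave open what change, if any, would give a numerical value in this assay.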